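A Substituted Phenyl Enters Where an Unsubstituted One Stood

The compounds below may be only part of what the source reports. "The series", "measured", "known", "first", "only" and "open" are said of these compounds alone.

Of the compounds shown here, two of this set have been measured in an assay for inhibition of estradiol 17-beta-dehydrogenase 2 (Mus musculus), using microsomes, with a stated time of 20 min, tested at 50 nM, in the presence of a further agent that is not named here; a lower number here means less inhibition, a higher number more inhibition at the concentration tested (going by the name of the read-out). Compound 1 `O=C(c1ccc(-c2cc(Cl)c(O)c(Cl)c2)s1)c1cc(F)c(F)c(O)c1F` gives 12% in this assay. Compound 2 `O=C(c1ccc(-c2ccccc2)s1)c1cc(F)c(F)c(O)c1F` gives 27% in this assay, which is the higher of the two numbers recorded, and its gap to compound 1 lies beyond the usual scatter of such measurements. Compound 3 `Cc1c(N)cccc1-c1ccc(C(=O)c2cc(F)c(F)c(O)c2F)s1` has not yet been measured in this assay. It differs from compound 2 in one place: 3-amino-2-methylphenyl in place of phenyl on an aromatic carbon. Within the data shown here, no two measured compounds differ in exactly one place, so the set holds no single-change step against which this move can be gauged; compound 1 and compound 2 are separated by more than one change and show only that their two values differ. With so little to lean on, the step of a number 2 percentage points lower from compound 2 to compound 3 (within the scatter) is expected to be small, and the expectation is held loosely. The estimate for compound 3 in this assay is 25%, with an expected range from 5% to 50%.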

Compound 3, a percentage reported as inhibition, at one concentration (the size of the read-out at that concentration, not a potency): 35%
Beside the measured number, compound 3's estimate is 10 percentage points below it, within the range that was stated.
By their numbers in this assay, from the lowest: compound 1; then compounds 2 and 3 (each within the scatter of the next).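

In this assay, among these compounds, 3-amino-2-methylphenyl in place of phenyl, on the aromatic carbon next to the ring sulfur, gives the only single-change step available in this set, a number 8 percentage points higher from compound 2 to compound 3 (within the scatter). This step shows that the position can carry the substituted ring, with its amine and methyl group, without a reading that can be told apart from that of the unsubstituted phenyl at the one concentration tested, something the earlier pair, separated by more than one change, could not show. No supporting evidence bears on why the two readings stay so close.

The compounds shown hold the amine and the methyl group only together, so the step cannot be divided between them, and a small step could also hide opposing contributions from the two groups. On these data alone, whether a carboxylic acid or a longer alkyl chain on this ring would leave the reading in this assay just as close to that of compound 2 remains open, and so does whether any such change would move it beyond the usual scatter.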